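Enlarging the furan-2-yl group of compound 3

This account rests on a few compounds, and the source may have more. Where it says the series, first, only, none or still open, it means among the compounds named here.

In a functional assay on HCT-116 cells (Homo sapiens), read by MTT assay, with a stated time of 72 h (a higher number here means a weaker inhibitor, a lower number a stronger inhibitor), compound 1 (`COc1ncnc2c1c(-c1ccccc1)cn2[C@@H]1O[C@H](CO)[C@@H](O)[C@H]1O`) gives > 20000 nM as a limit and not a number. Compound 2 (`C#Cc1cn([C@@H]2O[C@H](CO)[C@@H](O)[C@H]2O)c2ncnc(SC)c12`) gives 90 nM on the same read-out. Compound 3 (`CNc1ncnc2c1c(-c1ccco1)cn2[C@@H]1O[C@H](CO)[C@@H](O)[C@H]1O`) gives 440 nM and so has the higher of the two actual numbers, beyond the scatter from compound 2. The change to compound 4 (`CNc1ncnc2c1c(-c1cc3ccccc3o1)cn2[C@@H]1O[C@H](CO)[C@@H](O)[C@H]1O`) is 1-benzofuran-2-yl in place of furan-2-yl on an aromatic carbon and the rest of compound 3 stays the same. For the measured compounds named here, no measured pair differs in one place only, so the size of this step is a judgement. A move to a higher number in this assay is expected, beyond the scatter. The estimated step is a 9.1-fold higher number from compound 3 to compound 4 (0.96 log units; beyond the scatter) towards weaker inhibition. Compound 4 is estimated at 4000 nM with an expected range of 700 nM to 20000 nM for now.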

Compound 4, half-maximal inhibitory concentration: > 20000 nM
Compound 4 gave a limit, no number (the forecaster's own chance of this, stated with the estimate: 30%); middle value at least 5.0-fold (0.69 log units) away from the limit.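

In this assay, for the compounds shown here, 1-benzofuran-2-yl in place of furan-2-yl gives an at least 45-fold higher number from compound 3 to compound 4 (1.65 log units; beyond the scatter), the only step read at one place. This aromatic carbon therefore responds strongly to the group it carries, and the added six-membered aromatic ring of carbon only is enough for this large step. Compound 4 stands at a limit and not a number, so the step has a floor only: the limit of > 20000 nM in this assay, at which 2 of the 4 values shown sit.

On these data alone, whether a smaller addition to the furan-2-yl, such as a methyl or hydroxymethyl group, keeps a value close to that of compound 3 stays open.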